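A few compounds are considered here, and "the series" means these few. Any claim that something is new, unique, unknown or untested is made for them only; others in the source may bear on it.

Of the compounds shown here, three have been tested in a functional assay on HEK293 cells for agonist activity at trace amine-associated receptor 1 (Homo sapiens), read by cAMP accumulation, with a stated time of 30 min; a higher number here means a larger maximal response, a lower number a smaller maximal response. Compound 1 `Cc1ccccc1[C@H]1COC(N)=N1` gives 78% in this assay, compound 3 `NC1=N[C@@H](c2cccc(F)c2)CO1` gives 83%, and compound 2 `CCN(C[C@@H]1COC(N)=N1)c1ccccc1` gives 94%, the highest of the three numbers; its gap to compound 3 and its wider gap to compound 1 both lie beyond the usual scatter. Compound 4 `CCN(C[C@H]1COC(N)=N1)c1ccccc1` has not yet been measured. Compared with compound 2, (the two compounds have the same atoms and bonds and differ only in configuration as drawn: 1 of 1 stereo elements differ; a stereocentre at a saturated ring carbon is drawn R in compound 2 and S in compound 4). Among the measured compounds shown here, no two measured compounds differ in a single place, so nothing measured shows how large such a change can be in this assay. The step from compound 2 to compound 4 is expected to be a decrease of a number 24 percentage points lower from compound 2 to compound 4 (beyond the scatter), with wide uncertainty. Compound 4 is therefore estimated at 70%, in a range from 30% to 100%.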

Compound 4, largest response reached (Emax), in percent of the reference or control that the assay uses: 87%
For compound 4 the middle estimate is 17 percentage points below the measured one; measured number inside the range.
By their numbers in this assay, from the lowest: compounds 1, 3, 4 and 2 (each within the scatter of the next, the first and the last beyond it).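

Changing the stereocentre at the saturated ring carbon from R to S gives a number 7 percentage points lower from compound 2 to compound 4 (within the scatter) in this assay, so this maximal response does not separate the two configurations at this position. This is the first pair here in which a single change can be read directly, and the comparison is clean because nothing else varies: the fact that compounds 2 and 4 differ only in the configuration as drawn

Going by these compounds, whether the two configurations stay this close when the shared core carries a longer chain or a carboxylic acid remains open. The maximal response also leaves open how much of each compound is needed to reach it.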